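Removing One Bromine From a Cytotoxicity Series

This account rests on a few compounds, and the source may have more. Where it says the series, first, only, none or still open, it means among the compounds named here.

In an ADME assay on MT4 cells (Homo sapiens) for cytotoxicity, read by MTT assay, with a stated time of 4 days (on this read-out lower numbers stand for higher toxicity in this test and higher numbers for lower toxicity in this test), compound 1 `N#Cc1ccc(Nc2nc(N)nc(Oc3cccc4ccccc34)n2)cc1` gives 39100 nM.
In this assay compound 2 `CCNc1nc(Nc2ccc(C#N)cc2)nc(Oc2ccc3cc(Br)ccc3c2Br)n1` gives 74400 nM.
In this assay compound 3 `CCCNc1nc(Nc2ccc(C#N)cc2)nc(Oc2ccc3cc(Br)ccc3c2Br)n1` gives 134000 nM.

Compound 3 has the highest number of the three; compound 2 stays within the scatter of it, while compound 1 lies beyond. Compound 4 `CCCNc1nc(Nc2ccc(C#N)cc2)nc(Oc2ccc3ccccc3c2Br)n1` differs from compound 3 by hydrogen in place of bromo on an aromatic carbon. For the measured compounds named here, the only single-place step measured, a 1.8-fold higher number from compound 2 to compound 3 (0.26 log units; within the scatter), alters the chain and not a bromine, so it gives no direct guide. Compound 1 carries no bromine and shows a lower number than compound 3, but it also differs in its amine, so it is not a clean comparison. A modest drop is therefore expected, possibly within the scatter, so for compound 4 the estimate is 90000 nM, with a range from 40000 nM to 220000 nM, an expected step of a 1.5-fold lower number from compound 3 to compound 4 (0.17 log units; within the scatter).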

Compound 4, half-maximal cytotoxic concentration: > 263000 nM
Compound 4 gave a limit, no number; the forecaster's own chance of this, stated with the estimate: 10%; at least 2.9-fold (0.46 log units) between middle value and limit.
By their numbers in this assay, from the lowest: compounds 1, 2 and 3 (each within the scatter of the next, the first and the last beyond it). At a limit, above all of these: compound 4.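

In this assay compound 4 gives > 263000 nM, which is a limit and not a number. For the compounds shown here, the step reads an at least 1.9-fold higher number from compound 3 to compound 4 (0.29 log units; that floor lies within the scatter), so replacing bromo with hydrogen on this aromatic carbon brought no sign of the modest drop expected, something the earlier compounds could not show. The true size of the change stays unread, and its floor does not clear the scatter: the limit of > 263000 nM in this assay, at which 1 of the 4 values shown sits.

Still open, on these data alone, is whether a chlorine or a methyl group on this carbon would read like bromo or like hydrogen. Also open, as far as these compounds go, is what removing the remaining bromo would do.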